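The source may hold more compounds than are shown below. What is called first, only, known or untested is meant among the compounds shown, and "the series" means these compounds.

Compound 1 `COc1ccccc1S(=O)(=O)/C=C/c1ccc(Cl)cn1`: 100%. Compound 2 `COc1cccc(S(=O)(=O)/C=C/c2ccccn2)c1`: 100%.

In an ADME assay on BV-2 cells (Mus musculus) for cytotoxicity, with a stated time of 24 h, tested at 10 uM (on this read-out higher numbers stand for a weaker effect at the one concentration tested and lower numbers for a stronger effect), compound 1 gives 100%, and compound 2 gives 100%, which leaves compound 2 level with compound 1 at the digits shown, within the usual scatter. Going by the values given here, no step between measured compounds is available from these two readings alone. Compound 3 `COc1cccc(S(=O)(=O)/C=C/c2cccc(Cl)n2)c1` differs from compound 2 by chloro in place of hydrogen on an aromatic carbon. With both measured compounds at the same reading in this assay, no step beyond the scatter is expected in either direction. Compound 3 is therefore estimated at 100%, with a range from 88% to 108%. The expected step is no change at the digits printed from compound 2 to compound 3 (within the scatter).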

Compound 3, a percentage reported as activity, at one concentration (the size of the read-out at that concentration, not a potency): 100%
Estimate against measurement, compound 3: no gap at the digits printed; the range from low to high includes it.
By their numbers in this assay, from the lowest: compounds 1, 2 and 3 (each within the scatter of the next).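

In this assay, chloro in place of hydrogen on an aromatic carbon next to the ring nitrogen gives no change at the digits printed from compound 2 to compound 3 (within the scatter), the only single-place step that can be read among these compounds. At the one concentration tested, this position therefore takes a chlorine with no step beyond the scatter. No measured information offers an explanation for this reading. Going by these compounds, it remains open whether an amine, a carboxylic acid or a longer chain on the same carbon would give the same reading. Going by these compounds alone, whether chloro would still show no step at other concentrations also remains open.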